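Swapping the Acetyl Group: What to Expect for Compound 4

A few compounds are considered here, and "the series" means these few. Any claim that something is new, unique, unknown or untested is made for them only; others in the source may bear on it.

Three compounds have been measured in a functional assay on L1210 cells (Mus musculus), with a stated time of 1 days; a higher number here means a more potent compound, by a factor of ten per unit of this negative logarithm, a lower number a less potent compound:
compound 1 `CN(C)C(=O)OCCC1=C(N2CC2)C(=O)C(CCOC(=O)N(C)C)=C(N2CC2)C1=O` gives 4.62;
compound 2 `CCCC1=C(N2CC2)C(=O)C(CCC)=C(N2CC2)C1=O` gives 4.14;
compound 3 `CC(=O)C1=C(N2CC2)C(=O)C(C)=C(N2CC2)C1=O` gives 3.48.

Compound 3 stands lowest of the three, and both gaps, to compound 2 and to compound 1, lie beyond the usual scatter of repeated measurements. Compound 4 `CC1=C(N2CC2)C(=O)C(C(C)COC(N)=O)=C(N2CC2)C1=O` differs from compound 3 in one place: a group of 7 heavy atoms (4 carbon, 1 nitrogen, 2 oxygen; no ring) in place of a group of 3 heavy atoms (2 carbon, 1 oxygen; no ring), on a double-bonded ring carbon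

Among the compounds with values here, no measured pair shows exactly this change, so the step in this assay can only be estimated. An upward step seems more likely than a downward one, because compound 1, whose chains also end in a nitrogen-bearing group, gives 4.62, the highest of the three. Compound 4 is therefore expected to reach about 4.3, within 3.7 and 4.9, a step estimated at a number 0.82 log units higher from compound 3 to compound 4 (beyond the scatter).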

Compound 4, logarithm of the reciprocal of the active concentration, log(1/C): 5.31
For compound 4 the middle estimate is 1.01 log units below the measured one, outside the stated range (above it).
By their numbers in this assay, from the lowest: compound 3; then compound 2; then compound 1; then compound 4.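

At this double-bonded ring carbon, the acetyl group is not the limit of what the position accepts in this assay: the larger group of 7 heavy atoms, with its hydrogen-bond donor, gives a number 1.83 log units higher from compound 3 to compound 4 (beyond the scatter). A chain with a nitrogen-bearing end can therefore sit here with a large rise in the number. No measurement shown explains the size of this step. Which part of the new group carries the rise stays open: a plain propyl chain or a hydroxyethyl chain on this same carbon, with the rest of compound 4 kept, would separate the chain from its end.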